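Chloro added to the fused core of compound 2

A few compounds are considered here, and "the series" means these few. Any claim that something is new, unique, unknown or untested is made for them only; others in the source may bear on it.

Three compounds have numbers in an assay for inhibition of acyl-CoA (8-3)-desaturase (Homo sapiens); on this read-out lower numbers stand for stronger inhibition and higher numbers for weaker inhibition. Compound 1 `Clc1cccc(Nc2nccc3occc23)c1` gives 371 nM in this assay. Compound 2 `Clc1cccc(Nc2n[nH]c3ccccc23)c1` gives 84 nM. Compound 3 `Fc1cccc(Nc2n[nH]c3ccccc23)c1` gives 59 nM. Compound 2 stands second highest of the three: its nearest neighbour is compound 3, and the step of a 1.4-fold lower number from compound 2 to compound 3 (0.15 log units; within the scatter) lies within the scatter, while compound 1, which differs in the fused core, shows a clearly higher number.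

Compound 4 `Clc1cccc(Nc2n[nH]c3ccc(Cl)cc23)c1` is not yet measured. It differs from compound 2 by chloro in place of hydrogen on an aromatic carbon, placed on an aromatic carbon of a six-membered aromatic ring of carbon only, part of a fused system of two rings, meta to a fused ring and para to a fused ring.

Going by the values given here, no measured step touches the fused core of compound 2 in this way. Among the compounds with values here, the only single-point step at hand, from compound 2 to compound 3, swaps one halogen for another on the anilino ring and stays within the scatter, so it bears on compound 4 only indirectly. With nothing to anchor a direction, no step beyond the scatter is expected in this assay; the estimated step is a 1.1-fold lower number from compound 2 to compound 4 (0.05 log units; within the scatter). Compound 4 is therefore expected to give about 75 nM, with a range from 25 nM to 250 nM.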

Compound 4, half-maximal inhibitory concentration: 5 nM
Compound 4: the middle estimate sits 15-fold (1.18 log units) above what was measured; the measured number lies below the stated range.
By their numbers in this assay, from the lowest: compound 4; then compounds 3 and 2 (each within the scatter of the next); then compound 1.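

In this assay chloro in place of hydrogen on an aromatic carbon of the six-membered aromatic ring of carbon only, meta to a fused ring and para to a fused ring, gives a large change (a 17-fold lower number from compound 2 to compound 4 (1.23 log units; beyond the scatter)) that lies beyond the scatter. The earlier single-place step, a halogen exchange away from the shared core (a 1.4-fold lower number from compound 2 to compound 3 (0.15 log units; within the scatter)), lies within the scatter and gave no sign that one substituent could move the number this far, so this position on the core is the first site in the series shown to respond strongly to a single change. No measurement at hand accounts for the size of this step, and the reason for it stays unknown.

As far as these compounds go, whether the effect belongs to chloro itself or also holds for fluoro, methyl, methoxy, nitrile, an amine or a carboxylic acid at this position remains open. Also open, from the compounds shown here alone, is whether other aromatic carbons of the same ring respond in the same way, and whether the same chloro carries over to the core of compound 1.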